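Swapping an ethynyl group for a thiophene ring on a nucleoside core

This account rests on a few compounds, and the source may have more. Where it says the series, first, only, none or still open, it means among the compounds named here.

Compound 1 `C#Cc1cn([C@@H]2O[C@H](CO)[C@@H](O)[C@H]2O)c2ncnc(N(C)C)c12` carries an ethynyl group on its fused two-ring core and a dimethylamino group on the six-membered ring. Going by the values given here, in a functional assay on HeLa S3 cells (Homo sapiens) for antiproliferative activity, read by XTT assay, with a stated time of 72 h (on this read-out lower numbers stand for stronger inhibition and higher numbers for weaker inhibition), compound 1 gives 810 nM, the lowest of the two numbers known here. Compound 3 `C#Cc1cn([C@@H]2O[C@H](CO)[C@@H](O)[C@H]2O)c2ncnc(OC)c12`, in which methoxy replaces the dimethylamino group, gives 1730 nM in this assay, a step of a 2.1-fold higher number from compound 1 to compound 3 (0.33 log units; beyond the scatter). Compound 2 `C#Cc1cn([C@@H]2O[C@H](CO)[C@@H](O)[C@H]2O)c2ncnc(NC)c12`, with a methylamino group in that place, reaches only a limit of this assay, > 20000 nM; it is one of the values described by the limit of > 20000 nM in this assay, at which 1 of the 3 values shown sits. The step of an at least 24-fold higher number from compound 1 to compound 2 (1.39 log units; beyond the scatter) is therefore known only as a lower bound.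

Compound 4 `CN(C)c1ncnc2c1c(-c1cccs1)cn2[C@@H]1O[C@H](CO)[C@@H](O)[C@H]1O` is the compound not yet measured. It differs from compound 1 in one place: thiophen-2-yl in place of ethynyl on an aromatic carbon. Among the compounds with values here, none of the measured steps touches the ethynyl group; each of them changes the substituent on the six-membered ring instead, so they do not bear directly on this change. With the dimethylamino group kept, compound 4 is expected to stay within the same general region as compound 1, with a wide range: the estimate for compound 4 is 350 nM, between 50 nM and 2500 nM, meaning an expected step of a 2.3-fold lower number from compound 1 to compound 4 (0.36 log units; beyond the scatter).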

Compound 4, half-maximal inhibitory concentration: > 20000 nM
Compound 4: no number, only a limit; the forecaster's own chance of this, stated with the estimate: 10%; at least 57-fold (1.75 log units) between middle value and limit.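

Going by these compounds alone, the earlier compounds varied only the group on the six-membered ring, so this result is the first view of the position on the five-membered aromatic ring that holds the ethynyl group. With the dimethylamino group kept, putting thiophen-2-yl in place of ethynyl gives an at least 24-fold higher number from compound 1 to compound 4 (1.39 log units; beyond the scatter) in this assay, so a change at this position alone can remove the measurable activity of compound 1, and the ethynyl group cannot be freely exchanged for a ring of 5 heavy atoms. The result for compound 4 is a limit and not a number, so the step is only a lower bound, and compound 4 is the second compound to sit there: the limit of > 20000 nM in this assay, at which 2 of the 4 values shown sit.

With a single replacement shown at this position, it remains open whether the loss goes with the size of the new group, with the aromatic ring itself or with the absence of the triple bond, and a nitrile or a methyl group in that place would help to separate these. Also open, on these data alone, is whether thiophen-2-yl would have the same outcome with the methoxy group of compound 3 on the six-membered ring.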